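The source may hold more compounds than are shown below. What is called first, only, known or untested is meant among the compounds shown, and "the series" means these compounds.

In a functional assay on RXF 393 cells (Homo sapiens) for inhibition, read by sulforhodamine B assay, with a stated time of 48 h, tested at 10 uM (on this read-out higher numbers stand for more inhibition at the one concentration tested (going by the name of the read-out) and lower numbers for less inhibition), compound 2 `c1cn2cc(-c3ccsc3)nc(-c3ccc4ncn(C5CCCCC5)c4c3)c2n1` gives 8.63%, while compound 1 `Brc1cn2ccnc2c(-c2ccc3ncn(C4CCCCC4)c3c2)n1` gives 5.58%; the step of a number 3.1 percentage points higher from compound 1 to compound 2 (within the scatter) is within the scatter, so the two numbers are not told apart on this read-out. Compound 3 `Brc1ccc(-c2cn3ccnc3c(-c3ccc4ncn(C5CCCCC5)c4c3)n2)cc1` differs from compound 2 by 4-bromophenyl in place of thiophen-3-yl on an aromatic carbon. Among the compounds with values here, no measured step exchanges one aryl group for another here; the only step known, a number 3.1 percentage points higher from compound 1 to compound 2 (within the scatter), was small. Compound 3 is therefore expected to show no change beyond the scatter, with a number 0.6 percentage points lower from compound 2 to compound 3 (within the scatter). Compound 3 is estimated at 8%, between 0% and 20%.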

Compound 3, a percentage reported as inhibition, at one concentration (the size of the read-out at that concentration, not a potency): 34%
The estimate for compound 3 lay 26 percentage points below the measured number; the measured number lies above the stated range.
By their numbers in this assay, from the lowest: compounds 1 and 2 (each within the scatter of the next); then compound 3.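

In this assay, 4-bromophenyl in place of thiophen-3-yl on this aromatic carbon gives a number 25.4 percentage points higher from compound 2 to compound 3 (beyond the scatter), and 4-bromophenyl in place of bromo gives a number 28.4 percentage points higher from compound 1 to compound 3 (beyond the scatter). Within the data shown here, these are the first steps at this position beyond the scatter, so the position does respond to its substituent, and the two aromatic rings placed there do not read alike. Nothing available accounts for the rise.

Going by these compounds, it stays open whether the rise belongs to the six-membered ring or to its bromine. An unsubstituted phenyl or a 4-methoxyphenyl at this position would bear on that.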